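The source may report more compounds than this note shows. Statements on the series, on what has been measured and on what is new or still open speak of the compounds shown alone.

Compound 3 `Cc1ccc(Nc2ccc(N3CC4CC(C3)N4)nn2)cc1` and compound 1 `Fc1ccc(Nc2ccc(N3CC4CC(C3)N4)nn2)cc1` share one core; compound 2 `Cc1ccc(Nc2ccc(N3CC4CC(C3)N4)cn2)cc1` and the not yet measured compound 4 `Fc1ccc(Nc2ccc(N3CC4CC(C3)N4)cn2)cc1` share another. The difference between the two cores is not broken down here. In an assay on cell membranes for displacement of a labelled ligand from Neuronal acetylcholine receptor; alpha4/beta2 (Rattus norvegicus) (a lower number here means a stronger inhibitor, a higher number a weaker inhibitor), compound 3 gives 44.3 nM, compound 1 gives 868 nM and compound 2 gives 52.1 nM. Compound 2 and compound 3 lie within the scatter of each other, so no order between them is claimed. The change fluoro in place of methyl on an aromatic carbon gave a 20-fold higher number from compound 3 to compound 1 (1.29 log units; beyond the scatter), a large step on that core. The change fluoro in place of methyl on an aromatic carbon is the same change on the other core, at a place described in the same words, and among the compounds shown it occurs only on these two pairs. In this assay, going by the values given here, the expected step is a 17-fold higher number from compound 2 to compound 4 (1.24 log units; beyond the scatter), because a 20-fold higher number from compound 3 to compound 1 (1.29 log units; beyond the scatter) is the only measured instance of this change and nothing here shows the two cores responding differently. Compound 4 is accordingly estimated at 900 nM, with a range from 300 nM to 3000 nM, pending measurement.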

Compound 4, inhibition constant: 2.38 nM
Compound 4: the middle estimate sits 380-fold (2.58 log units) above what was measured, and the stated range ends above it.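

In this assay, fluoro in place of methyl on an aromatic carbon gave a 22-fold lower number from compound 2 to compound 4 (1.34 log units; beyond the scatter), so the change runs in opposite directions on the two cores: the same change on two cores in this assay, a 20-fold higher number (1.29 log units; beyond the scatter) from compound 3 to compound 1 and a 22-fold lower number (1.34 log units; beyond the scatter) from compound 2 to compound 4, 430-fold (2.63 log units) apart, beyond the scatter of two such steps. In this series, neither the size nor the direction of the step measured on one core can be carried to the other, even though compound 2 and compound 3, which both bear the 4-methylphenyl group, lie within the scatter of each other. Going by these compounds alone, what this does not show is why the cores part, since the difference between them is not broken down here and each core offers only one pair.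

The compounds shown leave open whether the reversal belongs to fluoro alone or also appears with other groups on that aromatic carbon, such as chloro, methoxy or nitrile. They also leave open how the two cores compare with plain hydrogen there, which would give each core a reference for both the methyl and the fluoro compound.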